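The source may report more compounds than this note shows. Statements on the series, on what has been measured and on what is new or still open speak of the compounds shown alone.

Measured so far:
compound 1 `Fc1ccccc1CSc1nnc(-c2cnccn2)o1`, 12500 nM
compound 2 `Clc1ccccc1CSc1nnc(-c2cnccn2)o1`, 12300 nM
compound 3 `Fc1ccc(CSc2nnc(-c3cnccn3)n2-c2ccccc2)cc1`, 10100 nM

In a functional assay on HepG2 cells (Homo sapiens) for antiproliferative activity, read by MTT assay, with a stated time of 48 h (on this read-out lower numbers stand for stronger inhibition and higher numbers for weaker inhibition), compound 1 gives 12500 nM and compound 2 gives 12300 nM. The two differ only by chloro in place of fluoro on an aromatic carbon, and the step is a 1.0-fold lower number from compound 1 to compound 2 (0.01 log units; within the scatter). Compound 3, with a different core, gives 10100 nM in this assay; the difference between the two cores is not broken down here. Compound 4 `Clc1ccc(CSc2nnc(-c3cnccn3)n2-c2ccccc2)cc1` is not yet measured. It differs from compound 3 by chloro in place of fluoro on an aromatic carbon. This is the same kind of change as that from compound 1 to compound 2, but there the group sits ortho to a large group, here para to a large group. Because a 1.0-fold lower number from compound 1 to compound 2 (0.01 log units; within the scatter), a similarly small step is expected from compound 3 to compound 4, a 1.0-fold lower number from compound 3 to compound 4 (0.00 log units; within the scatter). In this assay compound 4 is estimated at 10000 nM, between 5000 nM and 20000 nM.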

Compound 4, half-maximal inhibitory concentration: 15300 nM
For compound 4 the middle estimate is 1.5-fold (0.18 log units) below the measured one, and the stated range covers the measured number.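

In this assay, putting chloro in place of fluoro on the core of compound 3 gives a 1.5-fold higher number from compound 3 to compound 4 (0.18 log units; within the scatter). Set beside the same change on the core of compound 1, the two steps do not differ by more than ordinary repeat measurements would: the same change on two cores in this assay, a 1.0-fold lower number (0.01 log units; within the scatter) from compound 1 to compound 2 and a 1.5-fold higher number (0.18 log units; within the scatter) from compound 3 to compound 4, 1.5-fold (0.19 log units) apart, within the scatter of two such steps. This shows that, in these two pairs, the change has no readable effect on either core, but it does not show that the step would stay this small on other cores, and with both steps inside the scatter, it cannot reveal any real core dependence.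

The compounds shown leave open what a methoxy group, a nitrile or an amine would do in place of these halogens. From the compounds shown here alone, whether any such group would move the number beyond the scatter on either core also remains unknown.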